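Methyl for nitro on a thiosemicarbazone: expected cytotoxicity

The source may hold more compounds than are shown below. What is called first, only, known or untested is meant among the compounds shown, and "the series" means these compounds.

For the measured compounds named here, compound 2 `C=CCN(CC=C)C(=S)N/N=C\c1ccccc1[N+](=O)[O-]` carries the only number available in an ADME assay on Vero cells (Chlorocebus sabaeus) for cytotoxicity, read by MTT assay, with a stated time of 72 h (a lower number here means that less compound is tolerated, a higher number that more compound is tolerated), where compound 2 gives 205000 nM. Compound 1 `C=CCN(CC=C)C(=S)N/N=C\c1ccccc1O` has no number in this assay; there compound 1 is recorded as "not determined" (no result reported). Compound 3 `C=CCN(CC=C)C(=S)N/N=C\c1ccccc1C` is the next compound to be measured, and it differs from compound 2 by methyl in place of nitro on an aromatic carbon. Going by the values given here, no step between measured compounds is available to judge what this change does. He expects the step from compound 2 to compound 3 to stay within the usual scatter, a 1.3-fold lower number from compound 2 to compound 3 (0.11 log units; within the scatter), in either direction. Compound 3 is therefore estimated at 160000 nM in this assay, with a range from 60000 nM to 400000 nM.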

Compound 3, half-maximal cytotoxic concentration: > 228000 nM
Compound 3: no number, only a limit (the forecaster's own chance of this, stated with the estimate: 25%); at least 1.4-fold (0.15 log units) between middle value and limit.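

In this assay, for the compounds shown here, methyl in place of nitro on an aromatic carbon gives the first step at this position: an at least 1.1-fold higher number from compound 2 to compound 3 (0.04 log units; that floor lies within the scatter). Compound 3 gives > 228000 nM, which is a limit and not a number. The step therefore has only a floor, and its true size cannot be read because compound 3 sits at a limit: the limit of > 228000 nM in this assay, at which 1 of the 3 values shown sits.

From the compounds shown here alone, how far the true value of compound 3 lies beyond its limit stays open. So does what an amine or a carboxylic acid on this aromatic carbon would give in this assay.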